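Cytotoxicity notes on an amide series

This account rests on a few compounds, and the source may have more. Where it says the series, first, only, none or still open, it means among the compounds named here.

Measured compounds:
compound 1 `COc1ccc(-c2cnc(NC(=O)CCc3ccccc3)n2C)cc1`: > 100000 nM
compound 2 `Cn1c(-c2ccccc2)cnc1NC(=O)c1ccccc1`: > 100000 nM
compound 3 `COc1ccc2nc(NC(=O)c3ccc(F)cc3)n(C)c2c1`: > 100000 nM

In a toxicity assay on THP-1 cells (Homo sapiens) for inhibition (a lower number here means that less compound is tolerated, a higher number that more compound is tolerated), compound 1 gives > 100000 nM, which is a limit of the assay and not a number. Compound 2 also comes out at a limit, > 100000 nM. Compound 3 likewise reports only a limit, > 100000 nM. Compound 1 therefore stands at the limit of > 100000 nM in this assay, at which 3 of the 3 values shown sit, not apart from the other two, and no order among the three can be drawn.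

Compound 4 `COc1ccc(-c2cnc(NC(=O)c3cccc(C)c3)n2C)cc1` is not yet measured. Its change from compound 1 is 3-methylphenyl in place of phenethyl on a carbonyl carbon. Within the data shown here, no step between two measured compounds exists, so the size of such a change has no measured counterpart here. Given that compound 1 sits at the limit of > 100000 nM in this assay, at which 3 of the 3 values shown sit, together with every other value, no step beyond the scatter is expected in this assay, in either direction. Compound 4 is expected to give about 100000 nM, within 40000 nM to 300000 nM. The expected step is a number no higher from compound 1 to compound 4 (the limit leaves the size open), most likely again only a limit.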

Compound 4, half-maximal cytotoxic concentration: > 100000 nM
Compound 4 gave a limit, no number; the forecaster's own chance of this, stated with the estimate: 85%; the middle value sits exactly at the limit.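

In this assay compound 4 gives > 100000 nM, which is a limit and not a number. No step can be read from compound 1 to compound 4, because both values are limits: the limit of > 100000 nM in this assay, at which 4 of the 4 values shown sit. The compounds shown leave open at what concentration any of them becomes toxic to these cells.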